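A few compounds are considered here, and "the series" means these few. Any claim that something is new, unique, unknown or untested is made for them only; others in the source may bear on it.

Three compounds sharing one core and differing only in the five-membered aromatic ring attached to it have been measured in a functional assay for activation of Alpha-1A adrenergic receptor (Homo sapiens), read by calcium flux; a lower number here means that less compound is needed, a higher number that more compound is needed for the effect. Compound 1 `c1coc(-c2ccccc2NCC2=NCCN2)c1` gives 0.468 nM. Compound 2 `Cc1ncc(-c2ccccc2NCC2=NCCN2)o1` gives 110 nM, and compound 3 `c1csc(-c2ccccc2NCC2=NCCN2)c1` gives 2.24 nM. Among these three numbers compound 3 stands second highest: the nearer neighbour is shown by a 4.8-fold higher number from compound 1 to compound 3 (0.68 log units; beyond the scatter), the farther one by a 49-fold lower number from compound 2 to compound 3 (1.69 log units; beyond the scatter).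

Compound 4 `Cc1nc(-c2ccccc2NCC2=NCCN2)co1` has not yet been measured. It differs from compound 3 in one place: 2-methyl-1,3-oxazol-4-yl in place of thiophen-2-yl on an aromatic carbon. Among the compounds with values here, two measured steps bear on this change. Replacing furan-2-yl with 2-methyl-1,3-oxazol-5-yl gave a 240-fold higher number from compound 1 to compound 2 (2.37 log units; beyond the scatter), and replacing 2-methyl-1,3-oxazol-5-yl with thiophen-2-yl gave a 49-fold lower number from compound 2 to compound 3 (1.69 log units; beyond the scatter). Both show that a 2-methyl-1,3-oxazolyl ring at this place needed far more compound than furan-2-yl or thiophen-2-yl. The ring entering compound 4 is joined through a different carbon of the oxazole than the ring of compound 2, so the size of the step is uncertain. For compound 4 an upward step in this assay, beyond the scatter, is nonetheless expected, a 13-fold higher number from compound 3 to compound 4 (1.13 log units; beyond the scatter). Compound 4 is therefore estimated at 30 nM, within a range from 5 nM to 300 nM.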

Compound 4, half-maximal effective concentration: 324 nM
For compound 4 the middle estimate is 11-fold (1.03 log units) below the measured one, and the stated range ends below it.
By their numbers in this assay, from the lowest: compound 1; then compound 3; then compound 2; then compound 4.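

In this assay the same 2-methyl-1,3-oxazole ring, joined through a different carbon, gives a 2.9-fold higher number from compound 2 to compound 4 (0.47 log units; beyond the scatter) and so shows that the point of attachment matters at this position, though this step is small beside those that follow. Compound 4 also stands far from the two rings with 1 hetero atom, with a 140-fold higher number from compound 3 to compound 4 (2.16 log units; beyond the scatter) and a 690-fold higher number from compound 1 to compound 4 (2.84 log units; beyond the scatter) in the same assay, so the high number of compound 2 is not peculiar to one way of joining the oxazole: both rings with 2 hetero atoms need more compound than thiophen-2-yl and furan-2-yl, and none of the four compounds goes against this. Nothing measured here explains why these rings differ so widely.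

The shown compounds leave open whether the methyl group or the second hetero atom of the ring accounts for the rise, as each oxazole carries both. An oxazole without the methyl group, or one carrying an ethyl group or an amine in its place, would separate these two features.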